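Swapping the aryl imine on a weak antiproliferative core

The source may hold more compounds than are shown below. What is called first, only, known or untested is meant among the compounds shown, and "the series" means these compounds.

Measured compounds:
compound 1, `CN1CCN(c2ccc(Nc3ncc(/N=C/c4ccc(C(F)(F)F)cc4)c(NC4CCCC4)n3)cc2)CC1`, 80700 nM
compound 2, `CCOC(=O)/C=N/c1cnc(Nc2ccc(N3CCN(C)CC3)cc2)nc1NC(C)C`, 7590 nM
compound 3, `CC(C)Nc1nc(Nc2ccc(N3CCN(C)CC3)cc2)ncc1/N=C/c1cccs1`, > 100000 nM

All three share a core with a methylpiperazinyl-phenyl amine and an imine side chain. In a functional assay on HT-29 cells (Homo sapiens) for antiproliferative activity, read by MTT assay (on this read-out higher numbers stand for weaker inhibition and lower numbers for stronger inhibition), compound 2 gives 7590 nM. For compound 3 this assay reports only a limit, > 100000 nM, so no exact number is known for it (the limit of > 100000 nM in this assay, at which 1 of the 3 values shown sits). For the measured compounds named here, the one step on record, an at least 13-fold higher number from compound 2 to compound 3 (1.11 log units; beyond the scatter), shows that a change at the imine carbon can move the result substantially.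

Compound 4, `CC(C)Nc1nc(Nc2ccc(N3CCN(C)CC3)cc2)ncc1/N=C/c1ccc(C(F)(F)F)cc1`, differs from compound 3 by 4-(trifluoromethyl)phenyl in place of thiophen-2-yl on a carbon with a double bond to nitrogen. Going by the values given here, compound 1 carries the same 4-(trifluoromethyl)phenyl imine on a cyclopentylamino version of the core and gives 80700 nM in this assay, a weak result, but no step between compound 1 and compound 4 has been measured, so that value only hints at what the aryl group brings.

Given the limit for compound 3 and the weak value of compound 1, compound 4 is expected to remain a weak inhibitor, with a step of about an at least 1.1-fold lower number from compound 3 to compound 4 (0.04 log units; that floor lies within the scatter) that need not pass beyond the scatter. The estimate for compound 4 in this assay is 90000 nM, within a range from 30000 nM to 300000 nM.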

Compound 4, half-maximal inhibitory concentration: > 100000 nM
Compound 4: a limit, no number; the forecaster's own chance of this, stated with the estimate: 45%; middle value at least 1.1-fold (0.04 log units) from the limit.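

In this assay compound 4 is reported only as a limit, > 100000 nM, and compound 3 now shares that same limit: the limit of > 100000 nM in this assay, at which 2 of the 4 values shown sit. The step between these two compounds cannot be read, since both are limits, so thiophen-2-yl and 4-(trifluoromethyl)phenyl cannot be ranked against each other. What is new is that a second ring-bearing group on the carbon with a double bond to nitrogen now stands clearly apart from ethoxycarbonyl, with an at least 13-fold higher number from compound 2 to compound 4 (1.11 log units; beyond the scatter), while the change on the amine nitrogen gives an at least 1.2-fold higher number from compound 1 to compound 4 (0.09 log units; that floor lies within the scatter), so isopropyl and cyclopentyl cannot be told apart on this evidence.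

Among the compounds shown, ethoxycarbonyl alone gives a result well clear of the limit, and it remains open whether a carboxylic acid or a simple amide on the same carbon would keep that result. On these data alone, it also remains open whether a smaller group such as methyl, or a six-membered ring carrying an amine, would give a number that can be read at all in this assay.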